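Swapping piperidin-1-yl for diisopropylamino on a shared core

The source may hold more compounds than are shown below. What is called first, only, known or untested is meant among the compounds shown, and "the series" means these compounds.

In a functional assay on Huh-7 cells (Homo sapiens) for cytotoxicity, read by MTT assay, with a stated time of 3 days (a lower number here means that less compound is tolerated, a higher number that more compound is tolerated), compound 1 `[N-]=[N+]=NCc1ncnc2c1ncn2[C@@H]1O[C@H](CO)[C@@H](O)[C@H]1O` gives > 250000 nM as a limit of the assay and not as a number. Going by the values given here, compound 2 `OC[C@H]1O[C@@H](n2cnc3c(CN4CCCCC4)ncnc32)[C@H](O)[C@@H]1O` gives 87000 nM in this assay and so holds the only true number so far. Among the compounds with values here, the one measured step shows an at least 2.8-fold lower number from compound 1 to compound 2 (0.45 log units; beyond the scatter) on going from azido to piperidin-1-yl on a saturated chain carbon bound to an aromatic carbon. Compound 3 `CC(C)N(Cc1ncnc2c1ncn2[C@@H]1O[C@H](CO)[C@@H](O)[C@H]1O)C(C)C` keeps the shared core and carries diisopropylamino in place of piperidin-1-yl at that same place, with the difference diisopropylamino in place of piperidin-1-yl on a saturated chain carbon bound to an aromatic carbon between the two. Within the data shown here, no measured step starts from piperidin-1-yl, so the expectation rests on compound 2 at 87000 nM alone. The expected change is a 1.1-fold lower number from compound 2 to compound 3 (0.04 log units; within the scatter) and no step beyond the scatter is expected. In this assay the estimated value for compound 3 is 80000 nM with an expected range from 30000 nM to 200000 nM around it.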

Compound 3, half-maximal cytotoxic concentration: 18000 nM
Beside the measured number, compound 3's estimate is 4.4-fold (0.65 log units) above it, outside the stated range (below it).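

Going by these compounds alone, the exchange of piperidin-1-yl for diisopropylamino on a saturated chain carbon bound to an aromatic carbon gives a 4.8-fold lower number from compound 2 to compound 3 (0.68 log units; beyond the scatter), so in this assay this position tells two amines apart, where the earlier compounds had set only azido against a single amine. Less of the open-chain amine is tolerated than of the ring amine, and the change from azido to diisopropylamino gives an at least 13-fold lower number from compound 1 to compound 3 (1.14 log units; beyond the scatter). Compound 1 stands at a limit of the assay and not at a number, so that step is a bound only: the limit of > 250000 nM in this assay, at which 1 of the 3 values shown sits.

The compounds shown leave open whether the lower number goes with the loss of the ring or with the branched isopropyl groups. A smaller open-chain amine such as dimethylamino, or a ring amine such as morpholin-4-yl, would separate these readings.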